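The source may report more compounds than this note shows. Statements on the series, on what has been measured and on what is new or still open speak of the compounds shown alone.

Measured compounds in the series:
- compound 1, `Cc1nc(-c2ccc(Cl)s2)sc1COc1ccc2c(c1)OCC2CC(=O)O`: "not determined" (no result reported)
- compound 2, `Cc1cccc(-c2nc(C)c(COc3ccc4c(c3)OCC4CC(=O)O)s2)c1`: 119 nM
- compound 3, `Cc1nc(-c2cccc(C(F)(F)F)c2)sc1COc1ccc2c(c1)OCC2CC(=O)O`: "not determined" (no result reported)

All three share one core and differ only in the aryl group on the five-membered ring. Within the data shown here, in a functional assay on CHO cells for agonist activity at Free fatty acid receptor 1 (Homo sapiens), read by FLIPR and calcium flux (a lower number here means that less compound is needed, a higher number that more compound is needed for the effect), compound 2 gives 119 nM; this is the only number in hand, as compound 1 and compound 3 carry no result in this assay. Among the measured compounds shown here, compound 2 therefore stands alone and gives no measured step to lean on.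

The next compound, compound 4, `COc1ccc(-c2nc(C)c(COc3ccc4c(c3)OCC4CC(=O)O)s2)cc1`, differs from compound 2 in one place:
4-methoxyphenyl in place of 3-methylphenyl on an aromatic carbon
For the measured compounds named here, no measured pair shows what such an exchange of one aryl group for another does in this assay, so the direction of the step can only be guessed. Going by the values given here, with no reference step available, the expectation is for a change from compound 2 to compound 4 of a 1.3-fold higher number from compound 2 to compound 4 (0.13 log units; within the scatter), a step that is not expected to go beyond the usual scatter, with a slightly wider allowance toward weaker potency than toward stronger.

Compound 4 is accordingly estimated at 160 nM in this assay, with a range from 50 nM to 500 nM.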

Compound 4, half-maximal effective concentration: 123 nM
Compound 4: middle estimate off by 1.3-fold (0.11 log units), on the high side; the measured number falls inside the stated range.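

Among these compounds, this is the first readable step: in this assay, 4-methoxyphenyl in place of 3-methylphenyl on an aromatic carbon of the five-membered aromatic ring gives a 1.0-fold higher number from compound 2 to compound 4 (0.01 log units; within the scatter), so compound 2 and compound 4 cannot be told apart. Among the compounds shown here, the position thus accepts the exchange with no shift beyond the scatter, even though the entering group brings one more heavy atom and a hydrogen-bond acceptor, but the single pair changes the substituent and its place on the phenyl ring together, and the two contributions cannot be separated. No measurement of any property of these groups is at hand to account for this result.

Steps to compound 1 and compound 3 cannot be read, as neither has a number in this assay, and the aryl groups they carry remain uncompared with those of compound 2 and compound 4. Also open, as far as these compounds go, is how a phenyl group carrying a dimethylamino substituent, or a longer alkyl chain in place of the aryl group, would read at this carbon.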